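Replacing Propyl with 4-Bromobenzyl on the Sulfur Chain

The compounds below may be only part of what the source reports. "The series", "measured", "known", "first", "only" and "open" are said of these compounds alone.

Compound 1 `Cc1cc(Nc2cc(-c3ccccc3)[nH]n2)n2nc(SCc3ccc(F)cc3)nc2n1` gives 8110 nM in a functional assay on PC-9 cells (Homo sapiens) for inhibition, read by MTT assay, with a stated time of 72 h; a lower number here means a stronger inhibitor, a higher number a weaker inhibitor. Compound 2 `Cc1cc(Nc2cc(-c3cccs3)[nH]n2)n2nc(SCc3ccc(Br)cc3)nc2n1` gives 4890 nM in this assay. Compound 3 `CCCSc1nc2nc(C)cc(Nc3cc(-c4ccccc4)[nH]n3)n2n1` gives only > 50000 nM in this assay, a limit of the assay rather than a number.

Compound 3 thus sits at the limit of > 50000 nM in this assay, at which 1 of the 3 values shown sits, the weakest position that can be read. Compound 4 `Cc1cc(Nc2cc(-c3ccccc3)[nH]n2)n2nc(SCc3ccc(Br)cc3)nc2n1` differs from compound 3 in one place: 4-bromophenyl in place of ethyl on a saturated chain carbon bound to a sulfur. For the measured compounds named here, the only measured step that bears on this change is an at least 6.1-fold higher number from compound 1 to compound 3 (0.78 log units; beyond the scatter), which runs the opposite way. Compound 1 and compound 2 both carry a ring on the saturated chain carbon bound to a sulfur. Compound 4 is therefore expected to move by an at least 8.3-fold lower number from compound 3 to compound 4 (0.92 log units; beyond the scatter), back into their range. The estimate for compound 4 in this assay is 6000 nM, between 2500 nM and 15000 nM.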

Compound 4, half-maximal inhibitory concentration: 4760 nM
Compound 4: middle estimate off by 1.3-fold (0.10 log units), on the high side, within the range that was stated.
By their numbers in this assay, from the lowest: compounds 4, 2 and 1 (each within the scatter of the next). At a limit, above all of these: compound 3.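

Set against propyl on the sulfur, 4-bromobenzyl gives an at least 10-fold lower number from compound 3 to compound 4 (1.02 log units; beyond the scatter) in this assay. Bromo in place of fluoro gives a 1.7-fold lower number from compound 1 to compound 4 (0.23 log units; within the scatter), and phenyl in place of thiophen-2-yl on an aromatic carbon gives a 1.0-fold lower number from compound 2 to compound 4 (0.01 log units; within the scatter), so neither of these two changes separates the compounds. Compound 3 stands at a limit of the assay, not at a number: the limit of > 50000 nM in this assay, at which 1 of the 4 values shown sits.

The compounds shown leave open whether the aromatic ring itself matters or whether a longer chain on the sulfur would serve as well. They also leave open what an amine or a carboxylic acid in place of the bromo would do.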